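The source may report more compounds than this note shows. Statements on the series, on what has been measured and on what is new or still open speak of the compounds shown alone.

In a functional assay on PC-3 cells (Homo sapiens) for inhibition, read by sulforhodamine B assay, with a stated time of 48 h (on this read-out higher numbers stand for weaker inhibition of growth and lower numbers for stronger inhibition of growth), compound 1 `O=C(Cc1csc2nc(-c3ccc(Br)cc3)cn12)N/N=C/c1ccccc1` reads > 100000 nM, which is a limit of the assay and not a number. One added hydroxy gives compound 2 `O=C(Cc1csc2nc(-c3ccc(Br)cc3)cn12)N/N=C/c1ccccc1O` at 16600 nM, which is an at least 6.0-fold lower number from compound 1 to compound 2 (0.77 log units; beyond the scatter). Placed elsewhere, it gives compound 3 `O=C(Cc1csc2nc(-c3ccc(Br)cc3)cn12)N/N=C/c1ccc(O)cc1` at 23400 nM, which is an at least 4.2-fold lower number from compound 1 to compound 3 (0.63 log units; beyond the scatter). Compound 3 stands level with compound 2, since a 1.4-fold higher number from compound 2 to compound 3 (0.15 log units; within the scatter) stays within the scatter. Compound 4 `COc1cccc(OC)c1/C=N/NC(=O)Cc1csc2nc(-c3ccc(Br)cc3)cn12` has 2,6-dimethoxyphenyl in place of 4-hydroxyphenyl on a carbon with a double bond to nitrogen. Like compound 1, it carries no hydroxy, so the two hydroxy steps are the closest guide, and part of their gain may be lost. The expected change is modest, towards a higher number: a 2.1-fold higher number from compound 3 to compound 4 (0.33 log units; beyond the scatter). For compound 4 the estimated value is 50000 nM, with an expected range of 15000 nM to 100000 nM.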

Compound 4, concentration for total growth inhibition: 93300 nM
Compound 4: the middle estimate sits 1.9-fold (0.27 log units) below what was measured; low and high end bracket the measured number.
By their numbers in this assay, from the lowest: compounds 2 and 3 (each within the scatter of the next); then compound 4. At a limit, above all of these: compound 1.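

Replacing either hydroxyphenyl group with 2,6-dimethoxyphenyl gives a modest loss of growth inhibition: a 4.0-fold higher number from compound 3 to compound 4 (0.60 log units; beyond the scatter) and a 5.6-fold higher number from compound 2 to compound 4 (0.75 log units; beyond the scatter). At this position, then, adding groups to the phenyl ring does not by itself keep the gain seen with compound 2 and compound 3. Compound 1 stands at a limit and not at a number: the limit of > 100000 nM in this assay, at which 1 of the 4 values shown sits. Its last step therefore gives only a floor and cannot be read as a size: an at least 1.0-fold lower number from compound 1 to compound 4 (0.03 log units; that floor lies within the scatter)

From the compounds shown here alone, whether the loss follows from losing the hydroxy or from gaining two methoxy groups remains open. A phenyl ring carrying a single methoxy or an amine could help separate the two.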